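Swapping one halogen for another on an inactive core

A few compounds are considered here, and "the series" means these few. Any claim that something is new, unique, unknown or untested is made for them only; others in the source may bear on it.

Compound 1 `CCCCCn1c(N)nc2ccccc21` is the parent of this small set; in an assay on HEK293 cells for agonist activity at Toll-like receptor 8 (Homo sapiens), read by reporter gene assay (a lower number here means that less compound is needed, a higher number that more compound is needed for the effect), compound 1 gives 3230 nM. Compound 2 `CCCCCn1c(N)nc2c(OC)cccc21` carries a methoxy group on the ring; in this assay compound 2 gives 3740 nM, and the change a 1.2-fold higher number from compound 1 to compound 2 (0.06 log units; within the scatter) is within the scatter. Compound 3 `CCCCCn1c(N)nc2c(Cl)cccc21` carries a chloro group at the same place; in this assay compound 3 is reported as "not active" (no number reported), so no single number describes where it stands, only that it falls outside the measurable range while compounds 1 and 2 do not. Compound 4 `CCCCCn1c(N)nc2c(Br)cccc21` differs from compound 3 by bromo in place of chloro on an aromatic carbon. Going by the values given here, no measured step involves a halogen exchange, and the only measured step, from compound 1 to compound 2, concerns a different group and was within the scatter, so it offers little guidance here. Given that compound 3 shows no activity, compound 4 is expected to show at most weak activity, and quite possibly none. The estimate for compound 4 in this assay is 15000 nM, with a range from 4000 nM to 60000 nM.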

Compound 4, half-maximal effective concentration: "not active" (no number reported)
Compound 4 has no reported number here, and the estimate cannot be compared.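

In this assay compound 3 and compound 4 are both reported as not active, so swapping chloro for bromo gives no step that can be read, and no measurement here accounts for this. The compounds shown leave open whether any halogen at this place could give a measurable response.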